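The source may hold more compounds than are shown below. What is called first, only, known or untested is meant among the compounds shown, and "the series" means these compounds.

Working notes on the series. Two compounds of the shared core have been run so far. In a functional assay on the whole organism (strain Wister albino) for inhibition, with Rattus norvegicus as the target, read by paw edema, with stated times of 1 h and 4 h, at a dose of 50 mg/kg by the intraperitoneal route (on this read-out higher numbers stand for more inhibition at the one dose given (going by the name of the read-out) and lower numbers for less inhibition), compound 2, `CCOC(=O)c1c(-c2ccc(F)cc2)cc(-c2ccccc2)nc1Nc1ccccc1`, gives 76%, the highest of the two numbers. Compound 1, `CCOC(=O)c1c(-c2ccc(Cl)cc2)cc(-c2ccccc2)nc1Nc1ccc(Cl)cc1`, gives 65.2% in this assay, a number lower by more than the usual scatter; compound 1 differs from compound 2 in two places at once, so its gap cannot be assigned to either place alone.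

Next in line is compound 3, `CCOC(=O)c1c(-c2ccc(F)cc2)cc(-c2ccccc2)nc1Nc1ccc(Cl)cc1`, which differs from compound 2 by chloro in place of hydrogen on an aromatic carbon, the same place at which compound 1 also carries a chlorine. Within the data shown here, no single-change step has been measured in this assay, so the size of the step is open. The expectation is a small fall, at most near the edge of the scatter, in line with compound 1 sitting at 65.2%. Compound 3 is expected to give 70% in this assay, within 58% to 80%, meaning an estimated step of a number 6 percentage points lower from compound 2 to compound 3 (within the scatter).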

Compound 3, a percentage reported as inhibition, in the whole organism at one dose (the size of the read-out at that dose, not a potency): 78.4%
Estimate against measurement, compound 3: 8.4 percentage points below, and the stated range covers the measured number.
By their numbers in this assay, from the lowest: compound 1; then compounds 2 and 3 (each within the scatter of the next).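

In this assay, among these compounds, chloro in place of hydrogen on an aromatic carbon, para to a large group, gives a number 2.4 percentage points higher from compound 2 to compound 3 (within the scatter) and is the first single-change step: anilino and (4-chlorophenyl)amino are not told apart at this position in this pair. Fluoro in place of chloro on an aromatic carbon gives a number 13.2 percentage points higher from compound 1 to compound 3 (beyond the scatter) and so ties the earlier gap of compound 1 to the place that carries chloro in compound 1 and fluoro in compound 3, not to the (4-chlorophenyl)amino place, though only for these compounds. No measurement at hand offers a reason for either step.

Going by these compounds, whether a methoxy group, an amine or a carboxylic acid in place of chloro would also stay within the scatter of compound 2 remains open. Also open, on these data alone, is how hydrogen would compare with fluoro and chloro at the other halogen-bearing place.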